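A Ring in Place of a Branched Chain on the Amine

This account rests on a few compounds, and the source may have more. Where it says the series, first, only, none or still open, it means among the compounds named here.

Measured compounds:
compound 1, `CCC(C)NC(=C\C(=O)/C=C/c1ccc(O)c(OC)c1)/C=C/c1ccc(O)c(OC)c1`, 91%
compound 2, `COc1cc(/C=C/C(=O)/C=C(/C=C/c2ccc(O)c(OC)c2)NC2CCCCC2)ccc1O`, 88%
compound 3, `CCC(C)NC(=C\C(=O)/C=C/c1ccc(O)cc1)/C=C/c1ccc(O)cc1`, 102%

In a functional assay on Caco-2 cells (Homo sapiens), read by fluorescence, tested at 1 uM (on this read-out higher numbers stand for a weaker effect at the one concentration tested and lower numbers for a stronger effect), compound 1 gives 91%. Compound 2 differs from compound 1 only by cyclohexyl in place of sec-butyl on an amine nitrogen, and the step is a number 3 percentage points lower from compound 1 to compound 2 (within the scatter). Compound 3 gives 102%, the highest of the three; how its core differs from the core of compound 1 is not broken down here.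

Compound 4, `O=C(/C=C(/C=C/c1ccc(O)cc1)NC1CCCCC1)/C=C/c1ccc(O)cc1`, has not yet been measured in this assay. It differs from compound 3 by cyclohexyl in place of sec-butyl on an amine nitrogen, the same change, made at the same place, as from compound 1 to compound 2. The expected step is a number 3 percentage points lower from compound 3 to compound 4 (within the scatter), because the same change earlier gave a number 3 percentage points lower from compound 1 to compound 2 (within the scatter). Compound 4 is therefore estimated at 99%, expected between 88% and 110%.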

Compound 4, a percentage reported as activity, at one concentration (the size of the read-out at that concentration, not a potency): 97%
Compound 4: middle estimate off by 2 percentage points, on the high side; measured number inside the range.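

In this assay, putting cyclohexyl in place of sec-butyl on an amine nitrogen gives a number 5 percentage points lower from compound 3 to compound 4 (within the scatter). Set beside the earlier step, the change behaves alike on the two cores: the same change on two cores in this assay, a number 3 percentage points lower (within the scatter) from compound 1 to compound 2 and a number 5 percentage points lower (within the scatter) from compound 3 to compound 4, 2 percentage points apart, within the scatter of two such steps. This shows that swapping these two groups leaves the read-out within the usual scatter on both cores, but it does not show a real effect of the swap in either direction, and two cores say nothing about how a third would respond.

The compounds shown carry only sec-butyl or cyclohexyl on that nitrogen. Open, as far as these compounds go, is whether a different group there, such as a benzyl group, a longer chain or a chain ending in a carboxylic acid, would shift the read-out beyond the scatter.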